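A few compounds are considered here, and "the series" means these few. Any claim that something is new, unique, unknown or untested is made for them only; others in the source may bear on it.

Compound 1 `CC(C)(C)C[N+]1(C)CCc2c(sc(NC(=O)Nc3ccc(Cl)cc3)c2C(N)=O)C1` — in a functional assay (strain AB) with Danio rerio as the target, read by microscopy, with a stated time of 1 h (on this read-out higher numbers stand for an effect only at larger amounts of compound and lower numbers for an effect already at smaller amounts), compound 1 gives 290 nM.
Compound 2 `CC(C)(C)OC(=O)CN1CCc2c(sc(NC(=O)Nc3ccc(Cl)cc3)c2C(N)=O)C1` — in this assay compound 2 gives > 25000 nM, a limit of the assay and not a number.
Compound 3 `CC[N+]1(C)CCc2c(sc(NC(=O)Nc3ccc(Cl)cc3)c2C(N)=O)C1` — in this assay compound 3 gives 1960 nM.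

Compound 2 therefore stands at the limit of > 25000 nM in this assay, at which 1 of the 3 values shown sits, with no number of its own. Compound 4 `CC(C)(C)OC(=O)CCCCCN1CCc2c(sc(NC(=O)Nc3ccc(Cl)cc3)c2C(N)=O)C1` differs from it by 4-(tert-butoxycarbonyl)butyl in place of tert-butoxycarbonyl on a saturated chain carbon bound to an amine nitrogen in a ring. Going by the values given here, the only measured step at that same place is a 6.8-fold higher number from compound 1 to compound 3 (0.83 log units; beyond the scatter), in which the larger group goes with the lower number. Among the compounds with values here, no measured pair matches the change from compound 2 to compound 4 directly, so that step carries limited weight. A modest move toward lower numbers is nonetheless expected, an at least 2.0-fold lower number from compound 2 to compound 4 (0.31 log units; beyond the scatter), though compound 4 may still return only a limit. Compound 4 is estimated at 12000 nM, within a range from 3000 nM to 40000 nM.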

Compound 4, half-maximal effective concentration: 620 nM
Beside the measured number, compound 4's estimate is 19-fold (1.29 log units) above it; measured number outside the range, below it.
By their numbers in this assay, from the lowest: compound 1; then compound 4; then compound 3. At a limit, above all of these: compound 2.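

In this assay, the butyl chain placed before the tert-butoxycarbonyl end changes the read-out sharply: the result is an at least 40-fold lower number from compound 2 to compound 4 (1.60 log units; beyond the scatter). The value of compound 2 is a limit and not a number: the limit of > 25000 nM in this assay, at which 1 of the 4 values shown sits. Compound 4 thus shows that a group with no net charge at this place can still give a measured value, which compound 2 did not show. The compounds shown leave open whether this value depends on chain length or on the ester end. A longer chain, or a carboxylic acid or an amine at the chain end, could separate the two.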